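This account rests on a few compounds, and the source may have more. Where it says the series, first, only, none or still open, it means among the compounds named here.

Compound 1 `COc1cc(NC(=O)Nc2cc(Nc3ccc(OC)c(C)c3)ncn2)cc(OC)c1` is the starting point of this step. In a functional assay on NCI-H1581 cells (Homo sapiens) for inhibition, read by MTT assay, with a stated time of 48 h, tested at 10 uM (a higher number here means more inhibition at the concentration tested (going by the name of the read-out), a lower number less inhibition), compound 1 gives 19.7%, the lowest of the three numbers measured. Compound 2 `COc1ccc(F)cc1Nc1cc(NC(=O)Nc2c(Cl)cccc2Cl)ncn1` gives 73.1% and compound 3 `Cc1ccc(Nc2cc(NC(=O)Nc3c(Cl)cccc3Cl)ncn2)cc1F` gives 45.3%; both stand beyond the scatter above compound 1, with compound 3 the nearer of the two. Compounds 2 and 3 share a core that differs from that of compound 1 in the aryl carried by the urea, so their numbers are not directly comparable to compound 1.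

Compound 4 `COc1cc(NC(=O)Nc2cc(Nc3ccc(F)c(Cl)c3)ncn2)cc(OC)c1` is the compound to be measured. The change from compound 1 is 3-chloro-4-fluorophenyl in place of 4-methoxy-3-methylphenyl on a nitrogen on an aromatic ring. Within the data shown here, only one measured step bears on this position: a number 27.8 percentage points lower from compound 2 to compound 3 (beyond the scatter), which shows that exchanging the aryl on this nitrogen can move the read-out by a modest amount. That step replaced one group carrying a methoxy with one carrying a methyl, whereas the present change brings in a group carrying only halogens, so its direction cannot be read off from compounds 2 and 3 alone. A modest shift in either direction is plausible, with a small rise the more likely expectation. Compound 4 is therefore estimated at 32%, within a range of 12% to 55%, meaning an expected step of a number 12.3 percentage points higher from compound 1 to compound 4 (beyond the scatter).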

Compound 4, a percentage reported as inhibition, at one concentration (the size of the read-out at that concentration, not a potency): 53%
Beside the measured number, compound 4's estimate is 21 percentage points below it, and the stated range covers the measured number.
By their numbers in this assay, from the lowest: compound 1; then compounds 3 and 4 (each within the scatter of the next); then compound 2.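

In this assay the step of a number 33.3 percentage points higher from compound 1 to compound 4 (beyond the scatter) shows that, with the core of compound 1 held fixed, the aryl on this nitrogen can by itself carry a large change in the read-out. Among these compounds, the only earlier step at this place, which is a number 27.8 percentage points lower from compound 2 to compound 3 (beyond the scatter) came from compounds with a different aryl on the urea, and it could not give the direction of a change to a ring carrying only halogens. Here 3-chloro-4-fluorophenyl, with no hydrogen-bond acceptor, gives more inhibition at the concentration tested than 4-methoxy-3-methylphenyl, with one, although nothing available accounts for this rise.

The two rings differ in all their substituents at once, so the compounds shown do not separate the part played by the chlorine, the fluorine, the lost methoxy or the lost methyl. They also leave open whether the same change would hold with the aryl of compounds 2 and 3 on the urea, and how an aryl on this nitrogen bearing a basic amine such as morpholine or a carboxylic acid would read.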